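From 3-hydroxypropyl to 4-hydroxybutyl on a shared core

This account rests on a few compounds, and the source may have more. Where it says the series, first, only, none or still open, it means among the compounds named here.

- compound 1 `COc1ccc(C[C@H]2C(=O)N[C@@H](C)C(=O)N(C)[C@H]3Cc4ccc(cc4)Oc4cc(ccc4OC)C[C@@H](C(=O)N[C@H](C)C(=O)N[C@@H](CSC(C)=O)C(=O)N2C)N(C)C3=O)cc1` gives 9.77 nM 
- compound 2 `COc1ccc(C[C@H]2C(=O)N[C@@H](C)C(=O)N(C)[C@H]3Cc4ccc(cc4)Oc4cc(ccc4OC)C[C@@H](C(=O)N[C@H](C)C(=O)N[C@@H](CS)C(=O)N2C)N(C)C3=O)cc1` gives 363 nM 
- compound 3 `COc1ccc(C[C@H]2C(=O)N[C@@H](C)C(=O)N(C)[C@H]3Cc4ccc(cc4)Oc4cc(ccc4OC)C[C@@H](C(=O)N[C@H](C)C(=O)N[C@@H](CCCO)C(=O)N2C)N(C)C3=O)cc1` gives 174 nM 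

In a functional assay on P388 cells (Mus musculus) for cytotoxicity (a lower number here means a stronger inhibitor, a higher number a weaker inhibitor), compound 3 holds the middle of these three numbers. Compound 4 `COc1ccc(C[C@H]2C(=O)N[C@@H](C)C(=O)N(C)[C@H]3Cc4ccc(cc4)Oc4cc(ccc4OC)C[C@@H](C(=O)N[C@H](C)C(=O)N[C@@H](CCCCO)C(=O)N2C)N(C)C3=O)cc1` carries one change, hydroxymethyl in place of hydroxy on a saturated chain carbon, three bonds along the chain from a saturated ring carbon. Within the data shown here, no measured step alters this chain's length alone. The nearest guides swap the whole group: an 18-fold higher number from compound 1 to compound 3 (1.25 log units; beyond the scatter) is large, while a 2.1-fold lower number from compound 2 to compound 3 (0.32 log units; beyond the scatter) is modest. Since this change is far smaller than either swap, no step beyond the scatter is expected in this assay and no direction can be favoured. The expected result is a 1.0-fold higher number from compound 3 to compound 4 (0.01 log units; within the scatter) at the middle of the estimate. Compound 4 is estimated at 180 nM within a range of 70 nM to 500 nM on this measure.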

Compound 4, half-maximal inhibitory concentration: 219 nM
For compound 4 the middle estimate is 1.2-fold (0.09 log units) below the measured one; low and high end bracket the measured number.
By their numbers in this assay, from the lowest: compound 1; then compounds 3, 4 and 2 (each within the scatter of the next, the first and the last beyond it).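

In this assay, the step from 3-hydroxypropyl to 4-hydroxybutyl, a 1.3-fold higher number from compound 3 to compound 4 (0.10 log units; within the scatter), shows that this chain tolerates the added carbon without a reading beyond the scatter. The sulfanyl compound also stays within the scatter, with a 1.7-fold lower number from compound 2 to compound 4 (0.22 log units; within the scatter), whereas the acetylsulfanyl compound remains clearly apart, with a 22-fold higher number from compound 1 to compound 4 (1.35 log units; beyond the scatter). Nothing available explains these numbers. Still open, going by these compounds, is whether a longer chain, an amine or a carboxylic acid at the chain end, or an acetyloxy group in place of the hydroxy would bring the number closer to that of compound 1 .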